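Amide nitrogen substituent changes in an 8-hydroxyquinoline-carboxamide series

This account rests on a few compounds, and the source may have more. Where it says the series, first, only, none or still open, it means among the compounds named here.

Compound 1 `COc1cccc(NC(=O)c2ccc3cccc(O)c3n2)c1`: > 30000 nM
Compound 2 `Cc1ccc(NC(=O)c2ccc3cccc(O)c3n2)cc1`: > 30000 nM
Compound 3 `O=C(Nc1ccccc1F)c1ccc2cccc(O)c2n1`: > 30000 nM

Three compounds sharing one core have been run in an ADME assay on THP-1 cells (Homo sapiens) for cytotoxicity, read by WST assay, with a stated time of 24 h; a lower number here means a stronger inhibitor, a higher number a weaker inhibitor. Compound 1 `COc1cccc(NC(=O)c2ccc3cccc(O)c3n2)c1` sits at a limit of this assay, > 30000 nM, not at a number. Compound 2 `Cc1ccc(NC(=O)c2ccc3cccc(O)c3n2)cc1` likewise returns a limit, > 30000 nM. Compound 3 `O=C(Nc1ccccc1F)c1ccc2cccc(O)c2n1` also returns a limit, > 30000 nM. All three values therefore coincide with the limit of > 30000 nM in this assay, at which 3 of the 3 values shown sit, and compound 3 stands where every other compound stands.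

For the measured compounds named here, the one step measured within the set, a step that the two limits leave unreadable from compound 2 to compound 3, cannot be read in size, as both ends are limits.

Compound 4 `O=C(Nc1cccc(F)c1)c1ccc2cccc(O)c2n1` has not yet been measured in this assay. It differs from compound 3 by 3-fluorophenyl in place of 2-fluorophenyl on an amide-type nitrogen. Going by the values given here, the only step that bears on it is the unreadable one from compound 2 to compound 3, so no step of either direction can be drawn from it; three of three values sitting at the limit of > 30000 nM in this assay, at which 3 of the 3 values shown sit, suggest that compound 4 will also fall at that limit. Compound 4 is therefore expected to give 50000 nM, with a range of 20000 nM to 200000 nM. The expected step is a step that the limit leaves unreadable from compound 3 to compound 4, nothing beyond the scatter.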

Compound 4, half-maximal inhibitory concentration: > 30000 nM
Compound 4: only a limit was reported (the forecaster's own chance of this, stated with the estimate: 85%); the middle value lies beyond the limit too.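

In this assay no new step can be read: the steps to compound 4 from compound 1, compound 2 and compound 3 all have limits at both ends, so their sizes stay unreadable. The compounds shown leave open whether any substituent on the amide-type nitrogen would give a readable value, as all rest at one limit: the limit of > 30000 nM in this assay, at which 4 of the 4 values shown sit.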